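Swapping trifluoromethyl for chloro on a diaryl urea

The compounds below may be only part of what the source reports. "The series", "measured", "known", "first", "only" and "open" are said of these compounds alone.

Compound 1 `COc1cc2cc(Oc3ccc(NC(=O)Nc4cccc(C(F)(F)F)c4)cc3)c(C)nc2cc1OC` — 39900 nM
Compound 2 `COc1cc2cc(Oc3ccc(NC(=O)Nc4ccc(Cl)c(C(F)(F)F)c4)cc3)c(C)nc2cc1OC` — 14000 nM

Among the measured compounds shown here, in a functional assay on OVCAR-3 cells (Homo sapiens) for inhibition, read by sulforhodamine B assay, with a stated time of 48 h (on this read-out lower numbers stand for higher toxicity in this test and higher numbers for lower toxicity in this test), compound 2 holds the lower number of the two measured, and the single measured step, a 2.9-fold lower number from compound 1 to compound 2 (0.45 log units; beyond the scatter), lies beyond the scatter. Compound 3 `COc1cc2cc(Oc3ccc(NC(=O)Nc4ccc(Cl)c(Cl)c4)cc3)c(C)nc2cc1OC` differs from compound 2 by chloro in place of trifluoromethyl on an aromatic carbon. For the measured compounds named here, no measured step covers this exchange; the step from compound 1 to compound 2 concerns chloro in place of hydrogen at another position, so it offers only indirect guidance. With nothing directly bearing on the change, the expected step is a 1.4-fold higher number from compound 2 to compound 3 (0.15 log units; within the scatter), within the scatter. Compound 3 is therefore estimated at 20000 nM (range 8000 nM to 50000 nM).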

Compound 3, concentration lethal to 50% of the cells: 22200 nM
For compound 3 the middle estimate is 1.1-fold (0.05 log units) below the measured one; measured number inside the range.
By their numbers in this assay, from the lowest: compounds 2, 3 and 1 (each within the scatter of the next, the first and the last beyond it).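

In this assay the exchange of trifluoromethyl for chloro at this position, ortho to a chloro group, gives a 1.6-fold higher number from compound 2 to compound 3 (0.20 log units; within the scatter), so a group of four heavy atoms and a single chlorine cannot be told apart here. The wider change gives a 1.8-fold lower number from compound 1 to compound 3 (0.25 log units; within the scatter), so compound 3 cannot be separated from compound 1 either. No measured evidence explains these results.

From the compounds shown here alone, whether an amine or a carboxylic acid at this position would give a step beyond the scatter remains open. So does whether a nitrile would.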